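A few compounds are considered here, and "the series" means these few. Any claim that something is new, unique, unknown or untested is made for them only; others in the source may bear on it.

- compound 1 `CC(C)(C)c1nc(CCCCCC#N)c2c(N)c(C#N)c(N)nc2n1` gives 6000 nM 
- compound 2 `CC(C)(C)c1nc(-c2ccccn2)c2c(N)c(C#N)c(N)nc2n1` gives 87000 nM 
- compound 3 `CC(C)(C)c1nc(-c2ccncc2)c2c(N)c(C#N)c(N)nc2n1` gives 44000 nM 
- compound 4 `CC(C)(C)c1nc(-c2ncco2)c2c(N)c(C#N)c(N)nc2n1` has not yet been measured

In a physicochemical assay for solubility, in phosphate buffer, with a stated time of 18 h (on this read-out higher numbers stand for higher solubility and lower numbers for lower solubility), compound 3 lies within the scatter of compound 2 and well clear of compound 1, showing a 7.3-fold higher number from compound 1 to compound 3 (0.87 log units; beyond the scatter) beside a 15-fold higher number from compound 1 to compound 2 (1.16 log units; beyond the scatter) for the other pyridinyl compound. Compound 4 has 1,3-oxazol-2-yl in place of pyridin-4-yl on an aromatic carbon and keeps the shared core. Among the compounds with values here, no step beyond the scatter is expected because a 2.0-fold lower number from compound 2 to compound 3 (0.30 log units; within the scatter) is the only measured exchange of one aromatic group for another. The expected change is a 1.4-fold higher number from compound 3 to compound 4 (0.13 log units; within the scatter) in this read-out. Compound 4 is estimated at 60000 nM with an expected range of 20000 nM to 150000 nM in this measurement.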

Compound 4, solubility: 50000 nM
The estimate for compound 4 lay 1.2-fold (0.08 log units) above the measured number, within the range that was stated.
By their numbers in this assay, from the lowest: compound 1; then compounds 3, 4 and 2 (each within the scatter of the next).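

In this assay, a five-membered aromatic ring on this aromatic carbon reads level with both six-membered pyridinyl rings, with a 1.1-fold higher number from compound 3 to compound 4 (0.06 log units; within the scatter) and a 1.7-fold lower number from compound 2 to compound 4 (0.24 log units; within the scatter). The gap from the 5-cyanopentyl chain therefore now holds for three aromatic groups, with an 8.3-fold higher number from compound 1 to compound 4 (0.92 log units; beyond the scatter). No measurement given here accounts for this result. The compounds shown leave open whether a saturated ring such as morpholine, an amine or a phenyl ring on this carbon would read with the aromatic groups or with the chain. As far as these compounds go, a shorter chain or a chain without the nitrile also remains open.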